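The source may report more compounds than this note shows. Statements on the series, on what has been measured and on what is new or still open speak of the compounds shown alone.

Measured so far:
compound 1 `OC[C@H]1OC(n2cnc3c(-c4cc[nH]n4)ncnc32)[C@H](O)[C@@H]1O`: 750 nM
compound 2 `OC[C@H]1OC(n2cnc3c(-c4cc[nH]c4)ncnc32)[C@H](O)[C@@H]1O`: 1030 nM

In a functional assay on CCRF-CEM cells (Homo sapiens) for inhibition (on this read-out lower numbers stand for stronger inhibition and higher numbers for weaker inhibition), compound 1 gives 750 nM and compound 2 gives 1030 nM. Compound 2 has the higher of the two numbers, but the step of a 1.4-fold higher number from compound 1 to compound 2 (0.14 log units; within the scatter) lies within the scatter, so no order between the two is claimed.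

Compound 3 `OC[C@H]1OC(n2cnc3c(-c4ccc(F)cc4)ncnc32)[C@H](O)[C@@H]1O` differs from compound 2 by 4-fluorophenyl in place of 1H-pyrrol-3-yl on an aromatic carbon. Within the data shown here, the only measured step is the exchange of one five-membered aromatic ring for another, and it bears only loosely on the present change, which swaps a five-membered ring for a six-membered ring of carbon only. With that step being within the scatter, no step beyond the scatter is expected in this assay , though the wide uncertainty leans toward a higher number.

Compound 3 is expected at 1500 nM, in the range 500 nM to 5000 nM. This corresponds to an expected step of a 1.5-fold higher number from compound 2 to compound 3 (0.16 log units; within the scatter).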

Compound 3, half-maximal inhibitory concentration: 700 nM
Compound 3: the middle estimate sits 2.1-fold (0.33 log units) above what was measured, within the range that was stated.
By their numbers in this assay, from the lowest: compounds 3, 1 and 2 (each within the scatter of the next).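

In this assay, 4-fluorophenyl in place of 1H-pyrrol-3-yl gives a 1.5-fold lower number from compound 2 to compound 3 (0.17 log units; within the scatter), and in place of 1H-pyrazol-3-yl it gives a 1.1-fold lower number from compound 1 to compound 3 (0.03 log units; within the scatter). Across these three compounds, then, neither a six-membered aromatic ring of carbon only nor the absence of a hydrogen-bond donor in the group moves the number beyond the scatter at this aromatic carbon, which the earlier exchange between two five-membered rings could not show. No measurement at hand explains this flat result.

Whether an amine, a carboxylic acid or a longer alkyl chain at this aromatic carbon would stay within the same range remains open, since all three groups shown are single aromatic rings. The compounds shown differ only at this place, so the role of the hydroxyl groups on the shared core also stays open.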